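One Hydroxyl Instead of Three: Expected Cytotoxicity Shift

The source may hold more compounds than are shown below. What is called first, only, known or untested is meant among the compounds shown, and "the series" means these compounds.

In an ADME assay on THP-1 cells (Homo sapiens) for cytotoxicity (on this read-out higher numbers stand for weaker inhibition and lower numbers for stronger inhibition), compound 2 `COc1ccccc1-c1nnc(-c2ccc(C(=O)N/N=C/c3c(O)cc(O)cc3O)cc2)o1` gives 12400 nM, the lowest of the two numbers measured, while compound 1 `COc1ccccc1-c1nnc(-c2ccc(C(=O)N/N=C/c3ccccc3O)cc2)o1` gives 207000 nM. Among the compounds with values here, the only step seen, a 17-fold lower number from compound 1 to compound 2 (1.22 log units; beyond the scatter), accompanied 2,4,6-trihydroxyphenyl replacing 2-hydroxyphenyl. Compound 3 `COc1ccccc1-c1nnc(-c2ccc(C(=O)N/N=C/c3ccc(O)cc3)cc2)o1` differs from compound 2 in one place: 4-hydroxyphenyl in place of 2,4,6-trihydroxyphenyl on a carbon with a double bond to nitrogen. The entering group carries a single hydroxyl, as in compound 1 with its value of 207000 nM in this assay. The step is therefore expected to run the other way, as a large rise, an 8.1-fold higher number from compound 2 to compound 3 (0.91 log units; beyond the scatter). For compound 3 the estimated value is 100000 nM, within 30000 nM to 300000 nM.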

Compound 3, half-maximal inhibitory concentration: 261000 nM
For compound 3 the middle estimate is 2.6-fold (0.42 log units) below the measured one; measured number inside the range.
By their numbers in this assay, from the lowest: compound 2; then compounds 1 and 3 (each within the scatter of the next).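

In this assay, the place of a single hydroxyl on this ring makes no visible difference: 4-hydroxyphenyl in place of 2-hydroxyphenyl gives a 1.3-fold higher number from compound 1 to compound 3 (0.10 log units; within the scatter). Replacing 2,4,6-trihydroxyphenyl with 4-hydroxyphenyl gives a 21-fold higher number from compound 2 to compound 3 (1.32 log units; beyond the scatter), so among these three compounds only compound 2, with its 2,4,6-trihydroxyphenyl group, stands apart. Nothing available explains this difference. Still open, from the compounds shown here alone, is where a 2,4-dihydroxyphenyl group would fall between these numbers, and what an amine or a carboxylic acid on this ring would do in place of hydroxyl.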